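The source may report more compounds than this note shows. Statements on the series, on what has been measured and on what is new or still open speak of the compounds shown alone.

Compound 3 `CCNC(=O)c1cc(Oc2cccc(NC(=S)Nc3cccc(C(F)(F)F)c3)c2)ccn1` is the starting point for this step. Among the measured compounds shown here, in a functional assay on MDA-MB-231 cells (Homo sapiens) for cytotoxicity, read by MTT assay, with a stated time of 48 h (on this read-out lower numbers stand for stronger inhibition and higher numbers for weaker inhibition), compound 3 gives 53100 nM, the only actual number among the three measured compounds. Compound 1 `CCNC(=O)c1cc(Oc2cccc(NC(=S)Nc3ccc(F)c(F)c3)c2)ccn1` reaches only a limit of this assay, > 100000 nM. Compound 2 `O=C(NC1CCCCC1)c1cc(Oc2cccc(NC(=S)Nc3ccc(F)c(F)c3)c2)ccn1` likewise stops at a limit, > 100000 nM. Two of the three values therefore sit at the limit of > 100000 nM in this assay, at which 2 of the 3 values shown sit. For the measured compounds named here, the resulting step that the two limits leave unreadable from compound 1 to compound 2 cannot be read, while the one readable step is an at least 1.8-fold lower number from compound 1 to compound 3 (0.27 log units; that floor lies within the scatter). Compound 4 `O=C(c1cc(Oc2cccc(NC(=S)Nc3cccc(C(F)(F)F)c3)c2)ccn1)N1CCCC1` differs from compound 3 by pyrrolidin-1-yl in place of ethylamino on a carbonyl carbon. Going by the values given here, no measured step covers this change at the carbonyl carbon directly, and the nearest, a step that the two limits leave unreadable from compound 1 to compound 2, is unreadable. Compound 4 is therefore expected to show a 1.1-fold lower number from compound 3 to compound 4 (0.03 log units; within the scatter), nothing beyond the scatter. The estimate for compound 4 is 50000 nM, with a range from 20000 nM to 100000 nM.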

Compound 4, half-maximal inhibitory concentration: 35400 nM
Beside the measured number, compound 4's estimate is 1.4-fold (0.15 log units) above it; low and high end bracket the measured number.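

In this assay, among the compounds shown here, the swap on this carbonyl carbon gives a 1.5-fold lower number from compound 3 to compound 4 (0.18 log units; within the scatter), the first readable step at this place. Going from ethylamino to pyrrolidin-1-yl removes the amide hydrogen and adds a five-membered ring, yet the two values stay within the scatter of each other, so no gain or loss can be claimed. The earlier change on this amide nitrogen, ethyl to cyclohexyl, cannot be read: the limit of > 100000 nM in this assay, at which 2 of the 4 values shown sit.

The compounds shown leave open whether an amine, a carboxylic acid or a longer chain on this carbonyl carbon would move the number beyond the scatter.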